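Piperazine to piperidine swap on the aniline of compound 2

The source may report more compounds than this note shows. Statements on the series, on what has been measured and on what is new or still open speak of the compounds shown alone.

Measured compounds:
compound 1 `COc1ccc(Nc2ncc3ccc(-c4ccccc4OC)n3n2)cc1` — 0.117 h
compound 2 `COc1ccccc1-c1ccc2cnc(Nc3ccc(N4CCN(C[C@H](C)O)CC4)cc3)nn12` — > 0.666 h
compound 3 `COc1ccccc1-c1ccc2cnc(Nc3cccc(N4CCN(C[C@H](C)O)CC4)c3)nn12` — 0.0833 h

In an in vitro ADME assay on microsomes from liver (Mus musculus, strain CD1) for metabolic stability, using NADPH, with a stated time of 10 min, tested at 0.5 uM (on this read-out lower numbers stand for a shorter-lived compound and higher numbers for a longer-lived compound), compound 2 gives only a limit, > 0.666 h, and no number. That limit is the one at which one of the three values sits (the limit of > 0.666 h in this assay, at which 1 of the 3 values shown sits), so compound 2 stands at the upper edge of what this assay has reported for the series. Compound 1 gives 0.117 h and compound 3 gives 0.0833 h; compound 3 carries its 4-(2-hydroxypropyl)piperazin-1-yl at a different aromatic carbon than compound 2.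

The next compound, compound 4 `COc1ccccc1-c1ccc2cnc(Nc3ccc(C4CCN(C[C@H](C)O)CC4)cc3)nn12`, is not yet measured in this assay. Its change from compound 2: 1-(2-hydroxypropyl)piperidin-4-yl in place of 4-(2-hydroxypropyl)piperazin-1-yl on an aromatic carbon.

Among the compounds with values here, one measured step bears on this: an at least 5.6-fold higher number from compound 1 to compound 2 (0.75 log units; beyond the scatter). Within the data shown here, it shows that the group on this aromatic carbon matters to the half-life, but only the piperazine has been compared with methoxy; no measured step exchanges the piperazine ring itself. The ring size and the hydroxypropyl chain are kept, so a step is expected to stay small, with a modest lean towards a lower number since compound 2 sits at a limit.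

Expectation for compound 4: 0.5 h, range 0.2 h to 1.3 h, the step of an at least 1.3-fold lower number from compound 2 to compound 4 (0.12 log units; that floor lies within the scatter) being estimated.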

Compound 4, half-life: 0.117 h
Estimate against measurement, compound 4: 4.3-fold (0.63 log units) above; measured number below the stated range.
By their numbers in this assay, from the lowest: compounds 3, 1 and 4 (each within the scatter of the next). At a limit, above all of these: compound 2.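

In this assay, the ring itself decides the outcome: with the chain kept and the six-membered ring going from 2 hetero atoms to 1 at the same place, para to a large group, the result is an at least 5.6-fold lower number from compound 2 to compound 4 (0.75 log units; beyond the scatter). The 1-(2-hydroxypropyl)piperidin-4-yl group brings no gain over methoxy, with no change at the digits printed from compound 1 to compound 4 (within the scatter), so among these compounds a hydroxypropyl chain on a six-membered ring is not enough for the higher number, and only the 4-(2-hydroxypropyl)piperazin-1-yl group of compound 2 goes with it at this place. Compound 2 remains a limit and not a number, so the size of the ring swap is known only as a floor: the limit of > 0.666 h in this assay, at which 1 of the 4 values shown sits.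

Still open, as far as these compounds go, is whether the piperazine ring suffices without the hydroxypropyl chain, which a piperazine bearing a plain methyl group or a free amine hydrogen at the same place would show. A morpholine in place of the piperazine, or a longer chain ending in a carboxylic acid on the piperazine nitrogen, would show how much of the ring and how much of the chain the half-life depends on.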